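The compounds below may be only part of what the source reports. "The series", "measured", "known", "first", "only" and "open" are said of these compounds alone.

Of the compounds shown here, two built on one shared core have been tested in a functional assay on SK-OV-3 cells (Homo sapiens) for inhibition, read by sulforhodamine B assay, with a stated time of 48 h; on this read-out higher numbers stand for weaker inhibition of growth and lower numbers for stronger inhibition of growth. Compound 1 `N#C/C(=C\N1CCN(C(=O)c2ccco2)C1=S)C(=O)Nc1ccc(Cl)cc1` gives 41200 nM in this assay. Compound 2 `N#C/C(=C\N1CCN(C(=O)c2ccco2)C1=S)C(N)=O` gives 42600 nM in this assay. Among the measured compounds shown here, the only measured step, a 1.0-fold higher number from compound 1 to compound 2 (0.01 log units; within the scatter), puts hydrogen in place of 4-chlorophenyl on an amide-type nitrogen and leaves the read-out essentially where it was. Among the two numbers available, compound 2 holds the higher one, but its gap to compound 1 is within the scatter, so the two cannot be set in order.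

Compound 3 `N#C/C(=C\N1CCN(C(=O)c2ccco2)C1=S)C(=O)c1ccccc1` is not yet measured. It differs from compound 2 by phenyl in place of amino on a carbonyl carbon. For the measured compounds named here, the one measured step bears on this only loosely: it too swapped an aromatic ring for a small group at the amide end of the core, and that swap produced no change beyond the scatter. On that basis the step from compound 2 to compound 3 is expected to be small, a 1.1-fold lower number from compound 2 to compound 3 (0.03 log units; within the scatter), with no clear direction. Compound 3 is therefore estimated at 40000 nM in this assay, within a range from 15000 nM to 110000 nM.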

Compound 3, concentration for 50% growth inhibition: 37400 nM
For compound 3 the middle estimate is 1.1-fold (0.03 log units) above the measured one; measured number inside the range.
By their numbers in this assay, from the lowest: compounds 3, 1 and 2 (each within the scatter of the next).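

In this assay, the earlier step changed only what sat on the amide nitrogen, whereas this change replaces carbamoyl with benzoyl, so the amide nitrogen and its hydrogen-bond donor leave and a six-membered aromatic ring is attached directly to the carbonyl carbon. Even so, the result is a 1.1-fold lower number from compound 2 to compound 3 (0.06 log units; within the scatter), and the larger replacement of (4-chlorophenyl)amino by phenyl on the same carbon gives a 1.1-fold lower number from compound 1 to compound 3 (0.04 log units; within the scatter). Across these three compounds, then, neither the amide nitrogen nor the chlorine-bearing ring shifts the read-out beyond the scatter, and no measurement offered here explains this flat result.

The compounds shown leave open whether this carbonyl position tolerates every group or only those tried so far, as a carboxylic acid, a basic amine on a longer chain or a simple methyl group at that carbon could still move the number beyond the scatter. All three compounds also keep the rest of the shared core unchanged, so they cannot show how much changing the other parts of that core would alter growth inhibition.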